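Second nitrooxy group on a shortened ester chain

A few compounds are considered here, and "the series" means these few. Any claim that something is new, unique, unknown or untested is made for them only; others in the source may bear on it.

Compound 3 `Cc1cc(OC(=O)c2ccc(CCCO[N+](=O)[O-])cc2)n(-c2ccccc2)n1` and compound 1 `Cc1cc(OC(=O)c2ccc(CC(CO[N+](=O)[O-])O[N+](=O)[O-])cc2)n(-c2ccccc2)n1` share a core and differ by one change, (nitrooxy in place of hydrogen on a saturated chain carbon bound to two saturated chain carbons). In an ADME assay on a cell-free system (serum, Homo sapiens) for metabolic stability, read by HPLC, tested at 250 uM (a higher number here means that the compound lasts longer, a lower number that the compound disappears faster), compound 3 gives 0.0667 h and compound 1 gives 0.118 h, a step of a 1.8-fold higher number from compound 3 to compound 1 (0.25 log units; within the scatter). Compound 2 `Cc1cc(OC(=O)CCCCCO[N+](=O)[O-])n(-c2ccccc2)n1` carries a different chain on the same core; the difference between the two cores is not broken down here. In this assay compound 2 gives only a limit of the assay, < 0.0167 h. That is the limit of < 0.0167 h in this assay, at which 1 of the 3 values shown sits. Compound 4 `Cc1cc(OC(=O)CCCC(CO[N+](=O)[O-])O[N+](=O)[O-])n(-c2ccccc2)n1` has not been measured and differs from compound 2 by the same change, (nitrooxy in place of hydrogen on a saturated chain carbon bound to two saturated chain carbons). Because the earlier step was a 1.8-fold higher number from compound 3 to compound 1 (0.25 log units; within the scatter), a similarly small step is expected for compound 4, namely a step that the limit leaves unreadable from compound 2 to compound 4. Compound 4 is therefore estimated at 0.015 h in this assay, most likely again reported only as a limit.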

Compound 4, half-life in the serum assay: < 0.0167 h
Compound 4: no number, only a limit (the forecaster's own chance of this, stated with the estimate: 70%); the middle value does not contradict the limit.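

In the serum assay, compound 2 gives only a limit of the assay, not a number: < 0.0167 h. In the serum assay, compound 4 also gives only a limit of the assay, not a number: < 0.0167 h. No step between them can be read: the limit of < 0.0167 h in the serum assay, at which 2 of the 4 values shown sit.

The compounds shown leave open how long compound 2 and compound 4 actually last, and whether the nitrooxy change makes any difference for this pair.

In a physicochemical assay for lipophilicity, read by HPLC, measured as octanol-water partition, at pH 7 (on this read-out higher numbers stand for higher lipophilicity and lower numbers for lower lipophilicity), compound 2 gives 3.79 and compound 4 gives 3.95, a step of a number 0.16 log units higher from compound 2 to compound 4 (within the scatter).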